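Working notes: three measured compounds and one awaited

A few compounds are considered here, and "the series" means these few. Any claim that something is new, unique, unknown or untested is made for them only; others in the source may bear on it.

Measured so far:
compound 1 `CC(C)C(c1ccc(-c2ccc3cccc(F)c3c2)[nH]c1=O)N1CCCCS1(=O)=O`: 14 nM
compound 2 `CCn1ncc2c(F)cc(-c3ccc(C(CC)(CC)c4nnc(C)[nH]4)c(=O)[nH]3)cc21`: 34 nM
compound 3 `CCC(CC)(c1nnc[nH]1)c1ccc(-c2ccc3cccc(F)c3c2)[nH]c1=O`: 19 nM

In an assay on CHO cells for displacement of a labelled ligand from prostaglandin E2 receptor EP3 subtype (Homo sapiens), read by radioligand binding (a higher number here means a weaker inhibitor, a lower number a stronger inhibitor), compound 1 gives 14 nM, the lowest of the three numbers. Compound 3 stands nearest, and its value is within the usual scatter of that of compound 1, so the two cannot be ordered. Compound 2 gives 34 nM, and that gap to compound 1 lies beyond the scatter.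

The next compound is compound 4 `CC(C)C(Nc1nccs1)c1ccc(-c2ccc3cccc(F)c3c2)[nH]c1=O`, not yet measured in this assay. It keeps the core of compound 1 and differs in one place: a group of 6 heavy atoms (3 carbon, 2 nitrogen, 1 sulfur; one five-membered aromatic ring with 2 hetero atoms) in place of a group of 8 heavy atoms (4 carbon, 1 nitrogen, 2 oxygen, 1 sulfur; one six-membered non-aromatic ring with 2 hetero atoms), on a saturated chain carbon bound to an aromatic carbon and a saturated chain carbon. The group that leaves carries no hydrogen-bond donor; the group that enters carries one, and it is a five-membered aromatic ring in place of a six-membered non-aromatic ring.

Among the compounds with values here, no measured pair in this set spans such a change, so the step from compound 1 to compound 4 in this assay has no direct precedent here. The expectation is a small step, toward a higher number if anything, and quite possibly none beyond the scatter, so the estimated step is a 1.8-fold higher number from compound 1 to compound 4 (0.25 log units; within the scatter). Compound 4 is therefore expected to give about 25 nM, within the range 8 nM to 80 nM.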

Compound 4, inhibition constant: 9.4 nM
Compound 4: middle estimate off by 2.7-fold (0.42 log units), on the high side, within the range that was stated.
By their numbers in this assay, from the lowest: compounds 4, 1, 3 and 2 (each within the scatter of the next, the first and the last beyond it).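

In this assay, the change to (1,3-thiazol-2-yl)amino at the saturated chain carbon bound to an aromatic carbon and a saturated chain carbon gives a 1.5-fold lower number from compound 1 to compound 4 (0.17 log units; within the scatter), so this place accepts a five-membered aromatic ring in place of a six-membered non-aromatic ring without a step beyond the scatter. The six-membered ring of compound 1, with its double bonds outside aromatic rings, is therefore not required for a value in this range, and gaining a hydrogen-bond donor at this place brings no step beyond the scatter. No measurement available here bears on why two such different groups read alike.

This single pair changes ring size, ring type and the link to the chain carbon together, so it cannot show which of these matters, or whether the nitrogen link in the (1,3-thiazol-2-yl)amino group contributes at all. A plain amine, a carboxylic acid or a phenyl ring at the same place would test how far this tolerance extends beyond the two groups compared here.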